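The source may report more compounds than this note shows. Statements on the series, on what has been measured and on what is new or still open speak of the compounds shown alone.

Working notes on the series. Compound 2 `COc1ccc(C(=O)O[C@H]2CC(C)=C[C@H](OC(C)=O)[C@]3(C)[C@@H]2[C@](O)(C(C)C)C[C@@H]3O)cc1` and compound 1 `COc1ccc(C(=O)O[C@H]2CC(C)=C[C@H](O)[C@@]3(C)[C@@H](OC(C)=O)C[C@@](O)(C(C)C)[C@H]23)cc1` share one core and differ only in which of two oxygens carries the acetyl group. In a functional assay on Jurkat cells (Homo sapiens) for cytotoxicity, read by MTT assay, with a stated time of 72 h (on this read-out higher numbers stand for weaker inhibition and lower numbers for stronger inhibition), compound 2 gives 9100 nM, and in the same read-out compound 1 gives 5900 nM; the two numbers lie within the usual scatter of each other, so neither compound can be set apart from the other on these data. Compound 3 `COc1ccc(C(=O)O[C@H]2CC(C)=C[C@H](OC(C)=O)[C@@]3(C)[C@@H](OC(C)=O)C[C@@](O)(C(C)C)[C@H]23)cc1` has not yet been measured. Its difference from compound 2 is acetyl in place of hydrogen on an oxygen on a saturated carbon. With the acetyl present on either oxygen alone giving numbers that sit together, no step beyond the scatter is expected when both oxygens carry it. The expected step of a 1.2-fold lower number from compound 2 to compound 3 (0.08 log units; within the scatter) is therefore small, with no clear direction. For compound 3 the estimate in this assay is 7500 nM, within a range from 2500 nM to 22000 nM.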

Compound 3, half-maximal inhibitory concentration: 3300 nM
Estimate against measurement, compound 3: 2.3-fold (0.36 log units) above; low and high end bracket the measured number.
By their numbers in this assay, from the lowest: compounds 3, 1 and 2 (each within the scatter of the next, the first and the last beyond it).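

In this assay, among these compounds, the change from hydroxy to acetoxy on this oxygen gives a 2.8-fold lower number from compound 2 to compound 3 (0.44 log units; beyond the scatter) and is the first step that stands beyond the scatter, though only a modest one. The same change on the other oxygen gives a 1.8-fold lower number from compound 1 to compound 3 (0.25 log units; within the scatter) and so cannot be read as a change, which means the diacetate is set apart from only one of the two monoacetates. No measurement bearing on the cause of the step is at hand.

On these data alone, whether a butanoyl chain or a methyl ether on this oxygen would behave like acetyl remains open. Also open, as far as these compounds go, is whether the step seen in this one cell line would hold with a benzoyl group in place of the acetyl.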